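Methyl to methoxy on the aryl amine: cytotoxicity notes

The source may report more compounds than this note shows. Statements on the series, on what has been measured and on what is new or still open speak of the compounds shown alone.

Of the compounds shown here, three on a shared core have been measured in a functional assay on PC-3 cells (Homo sapiens) for cytotoxicity, read by MTT assay, with a stated time of 72 h; on this read-out lower numbers stand for stronger inhibition and higher numbers for weaker inhibition. Compound 1 `COc1ccccc1Nc1nc(SCc2ccc(C(F)(F)F)cc2)nc2ccccc12` gives 14100 nM. Compound 2 `Cc1ccccc1Nc1nc(SCc2ccc(C(F)(F)F)cc2)nc2ccccc12` gives 36900 nM, and compound 3 `Cc1ccc(Nc2nc(SCc3ccc(C(F)(F)F)cc3)nc3ccccc23)cc1` gives 21100 nM. Compound 4 `COc1ccc(Nc2nc(SCc3ccc(C(F)(F)F)cc3)nc3ccccc23)cc1` has not yet been measured.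

Compounds 2 and 3 have the same atoms, joined differently: 4-methylphenyl in place of 2-methylphenyl on a nitrogen on an aromatic ring. The step between them, a 1.7-fold lower number from compound 2 to compound 3 (0.24 log units; within the scatter), lies within the scatter, as does a 1.5-fold higher number from compound 1 to compound 3 (0.18 log units; within the scatter). Within the data shown here, the one change that moves beyond the scatter is methoxy in place of methyl on an aromatic carbon, which yields a 2.6-fold lower number from compound 2 to compound 1 (0.42 log units; beyond the scatter).

The same kind of change leads from compound 3 to compound 4: methoxy in place of methyl on an aromatic carbon. The place is not the same word for word: in compound 1 the methoxy sits ortho to a large group, whereas in compound 4 it sits para to a large group, so this is the same kind of change rather than the same change. Among the measured compounds shown here, only one earlier instance exists, so the expectation rests on a single step.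

Compound 4 is expected to come in near 11000 nM, with a range from 5500 nM to 25000 nM, because compound 3 stands at 21100 nM and the earlier step was a 2.6-fold lower number from compound 2 to compound 1 (0.42 log units; beyond the scatter). That expectation means an estimated step of a 1.9-fold lower number from compound 3 to compound 4 (0.28 log units; within the scatter). It is set somewhat smaller than the earlier step: the place differs, and a 1.5-fold higher number from compound 1 to compound 3 (0.18 log units; within the scatter) and a 1.7-fold lower number from compound 2 to compound 3 (0.24 log units; within the scatter) both lie within the scatter.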

Compound 4, half-maximal inhibitory concentration: 16700 nM
For compound 4 the middle estimate is 1.5-fold (0.18 log units) below the measured one, within the range that was stated.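

In this assay, methoxy in place of methyl on an aromatic carbon now gives a 1.3-fold lower number from compound 3 to compound 4 (0.10 log units; within the scatter), and the two readings of this change do not differ by more than the scatter allows: the same change on two cores in this assay, a 2.6-fold lower number (0.42 log units; beyond the scatter) from compound 2 to compound 1 and a 1.3-fold lower number (0.10 log units; within the scatter) from compound 3 to compound 4, 2.1-fold (0.32 log units) apart, within the scatter of two such steps. This fits one shared effect of the change on both aryl amines, but it rests on two pairs, and the second step alone lies within the scatter, so it does not establish that the change lowers the number when methoxy sits para to a large group, nor that the step keeps one size from core to core. Of the steps that alter the whole aryl group, a 2.2-fold lower number from compound 2 to compound 4 (0.34 log units; beyond the scatter) is modest and combines a change of group with a change of place, while a 1.2-fold higher number from compound 1 to compound 4 (0.07 log units; within the scatter) gives no separation between 4-methoxyphenyl and 2-methoxyphenyl.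

From the compounds shown here alone, all four compounds carry only methyl or methoxy on the aryl amine, so it remains open whether a hydroxy group, an amine or a longer chain such as ethoxy would follow the same course. Going by these compounds, the trifluoromethyl group is also common to all four, and whether the methoxy step holds with a carboxylic acid in its place is equally open.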